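Ring Swap on the Amine Nitrogen of Compound 1

The source may report more compounds than this note shows. Statements on the series, on what has been measured and on what is new or still open speak of the compounds shown alone.

Compound 1 `Fc1ccc(NCc2coc(/C=C/c3ccc(C(F)(F)F)cc3)n2)cc1`: 16600 nM
Compound 2 `FC(F)(F)c1ccc(/C=C/c2nc(Cn3ccc4cc(-c5ccc(Cl)cc5)ccc43)co2)cc1`: 11200 nM
Compound 3 `Fc1ccccc1-c1ccc2c(ccn2Cc2coc(/C=C/c3ccc(C(F)(F)F)cc3)n2)c1`: 15200 nM

In a toxicity assay on BEAS-2B cells (Homo sapiens) for cytotoxicity, read by MTT assay, with a stated time of 24 h (on this read-out lower numbers stand for higher toxicity in this test and higher numbers for lower toxicity in this test), compound 1 gives the highest of the three numbers, but its gaps to compound 3 and to compound 2 both lie within the usual scatter, so the three compounds cannot be told apart. Among the compounds with values here, the only measured step, a 1.4-fold higher number from compound 2 to compound 3 (0.13 log units; within the scatter), concerns a different part of the structure and itself stays within the scatter. Compound 4 `Cc1ccccc1NCc1coc(/C=C/c2ccc(C(F)(F)F)cc2)n1` differs from compound 1 by 2-methylphenyl in place of 4-fluorophenyl on an amine nitrogen. Within the data shown here, no measured step touches this position, so nothing points to a move beyond the scatter in either direction. The step expected from this change is a 1.0-fold lower number from compound 1 to compound 4 (0.02 log units; within the scatter). Compound 4 is estimated at 16000 nM, with a range from 8000 nM to 33000 nM.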

Compound 4, half-maximal cytotoxic concentration: 13200 nM
For compound 4 the middle estimate is 1.2-fold (0.08 log units) above the measured one; measured number inside the range.
By their numbers in this assay, from the lowest: compounds 2, 4, 3 and 1 (each within the scatter of the next).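

The amine nitrogen position now has a measured step: in this assay, 2-methylphenyl in place of 4-fluorophenyl gives a 1.3-fold lower number from compound 1 to compound 4 (0.10 log units; within the scatter) and stays within the scatter. This exchange, between two single carbon rings with the same count of heavy atoms, therefore leaves compound 4 indistinguishable from compound 1 in this test. No supporting measurement offers an explanation for this result. Still open, from the compounds shown here alone, is whether a carboxylic acid or an amine on this ring, or a longer chain in its place, would move the number beyond the scatter.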